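Adding a second trifluoromethyl group: compound 4 expected

This account rests on a few compounds, and the source may have more. Where it says the series, first, only, none or still open, it means among the compounds named here.

Measured so far in an ADME assay on the whole organism with Oryza sativa as the target, tested at 1 uM; on this read-out higher numbers stand for a weaker effect at the one concentration tested and lower numbers for a stronger effect:
compound 1, `C[C@H](NC(=O)Nc1cccc(C(F)(F)F)c1)c1ccccc1`: 93%
compound 2, `CCOC(=O)c1cccc(NC(=O)N[C@@H](C)c2ccccc2)c1`: 99%
compound 3, `CC(=O)c1cccc(NC(=O)N[C@@H](C)c2ccccc2)c1`: 95%

All three compounds share one core and differ only in the group on the aromatic ring. Compound 1 stands close to the other two: the step of a number 6 percentage points higher from compound 1 to compound 2 (within the scatter) and the step of a number 2 percentage points higher from compound 1 to compound 3 (within the scatter) both stay within the scatter, as does a number 4 percentage points lower from compound 2 to compound 3 (within the scatter).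

Compound 4, `C[C@H](NC(=O)Nc1cc(C(F)(F)F)cc(C(F)(F)F)c1)c1ccccc1`, keeps the trifluoromethyl group of compound 1 and adds a second one: trifluoromethyl in place of hydrogen on an aromatic carbon. Among the compounds with values here, no measured step adds a group to an otherwise unchanged ring; the steps from compound 1 only swap the trifluoromethyl for another group, and none of them moved the number beyond the scatter. On that basis no step beyond the scatter is expected for compound 4 in this assay, no change at the digits printed from compound 1 to compound 4 (within the scatter), so compound 4 is estimated at 93%, between 84% and 100%.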

Compound 4, a percentage reported as activity, at one concentration (the size of the read-out at that concentration, not a potency): 95%
Compound 4: middle estimate off by 2 percentage points, on the low side; low and high end bracket the measured number.
By their numbers in this assay, from the lowest: compounds 1, 3, 4 and 2 (each within the scatter of the next).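

Until now the steps only swapped the trifluoromethyl for another group, whereas this one adds a group on an aromatic carbon that carried hydrogen. In this assay, the second trifluoromethyl gives a number 2 percentage points higher from compound 1 to compound 4 (within the scatter), so adding to the ring of compound 1 at this position moves the number no more than the earlier swaps did. Nothing available here explains this result.

From the compounds shown here alone, whether an amine or a carboxylic acid on this same carbon would also stay within the scatter remains open. So does whether any group at this position can shift the number beyond the scatter.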